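A few compounds are considered here, and "the series" means these few. Any claim that something is new, unique, unknown or untested is made for them only; others in the source may bear on it.

In a functional assay on MCF7 cells (Homo sapiens) for cytotoxicity, read by MTT assay and propidium iodide staining, with a stated time of 24 h (on this read-out lower numbers stand for stronger inhibition and higher numbers for weaker inhibition), compound 1 `CCOc1ccccc1-c1nnc(SCC(=O)c2ccccc2)o1` gives 2670 nM, while compound 2 `O=C(CSc1nnc(-c2ccccc2F)o1)c1ccc(Br)cc1` gives 240 nM, the lower of the two numbers by a gap beyond the usual scatter. Compound 3 `CCOc1ccccc1-c1nnc(SCC(=O)c2ccc(Br)cc2)o1` differs from compound 2 in one place, with ethoxy in place of fluoro on an aromatic carbon. For the measured compounds named here, no measured pair shows this change alone, but compound 1 also carries ethoxy and gives 2670 nM, so weaker inhibition seems likely. The expected change is modest but beyond the scatter: a 2.7-fold higher number from compound 2 to compound 3 (0.43 log units; beyond the scatter). Compound 3 is estimated at 650 nM, with an expected range of 180 nM to 2400 nM.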

Compound 3, half-maximal inhibitory concentration: 460 nM
The estimate for compound 3 lay 1.4-fold (0.15 log units) above the measured number; low and high end bracket the measured number.
By their numbers in this assay, from the lowest: compounds 2 and 3 (each within the scatter of the next); then compound 1.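

Ethoxy in place of fluoro on this aromatic carbon, ortho to a large group, gives a 1.9-fold higher number from compound 2 to compound 3 (0.28 log units; within the scatter), so this larger group is accommodated here with no change beyond the scatter. For the compounds shown here, with ethoxy held in place, bromo in place of hydrogen on an aromatic carbon gives a 5.8-fold lower number from compound 1 to compound 3 (0.76 log units; beyond the scatter), the only step here beyond the scatter. No measurement at hand explains either result. On these data alone, whether an amine, a carboxylic acid or a longer chain would be accommodated at the ethoxy position remains open. So does whether bromo would give a similar step alongside fluoro.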